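A few compounds are considered here, and "the series" means these few. Any claim that something is new, unique, unknown or untested is made for them only; others in the source may bear on it.

In an assay on C3H 10T1/2 cells for inhibition of Sonic hedgehog protein (Mus musculus), read by a luciferase reporter (on this read-out lower numbers stand for stronger inhibition and higher numbers for weaker inhibition), three measured compounds share one core and differ in a single group. Compound 1 `Cc1nc(C(F)(F)F)ccc1C(=O)Nc1ccc(Cl)c(-c2nc3ccccc3[nH]2)c1` carries a 1H-benzimidazol-2-yl group and gives 12 nM. Compound 2 `Cc1nc(C(F)(F)F)ccc1C(=O)Nc1ccc(Cl)c(-c2nc3ccccc3s2)c1` carries a 1,3-benzothiazol-2-yl group instead and gives 70 nM. Compound 3 `Cc1nc(C(F)(F)F)ccc1C(=O)Nc1ccc(Cl)c(-n2cc3ccccc3n2)c1` carries a 2H-indazol-2-yl group and gives 80 nM, the highest of the three numbers; its gap to compound 2 is within the scatter, while its gap to compound 1 is beyond it, as the step of a 6.7-fold higher number from compound 1 to compound 3 (0.82 log units; beyond the scatter) shows. The step of a 5.8-fold higher number from compound 1 to compound 2 (0.77 log units; beyond the scatter) is of the same modest size, and the step of a 1.1-fold higher number from compound 2 to compound 3 (0.06 log units; within the scatter) is within the scatter.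

Compound 4 `Cc1nc(C(F)(F)F)ccc1C(=O)Nc1ccc(Cl)c(C(=O)Nc2ccccc2)c1` has not yet been measured in this assay. It differs from compound 3 in one place: phenylcarbamoyl in place of 2H-indazol-2-yl on an aromatic carbon. Within the data shown here, no measured step exchanges a bicyclic aromatic group for a phenylcarbamoyl group, so the two steps that bear on the question only loosely are a 5.8-fold higher number from compound 1 to compound 2 (0.77 log units; beyond the scatter) and a 6.7-fold higher number from compound 1 to compound 3 (0.82 log units; beyond the scatter), both modest. Compound 4 is therefore expected to give a number close to that of compound 3 or somewhat higher, with a step of a 1.9-fold higher number from compound 3 to compound 4 (0.27 log units; within the scatter). The estimate for compound 4 is 150 nM, in a range from 40 nM to 600 nM.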

Compound 4, half-maximal inhibitory concentration: 140 nM
For compound 4 the middle estimate is 1.1-fold (0.03 log units) above the measured one; the range from low to high includes it.
By their numbers in this assay, from the lowest: compound 1; then compounds 2, 3 and 4 (each within the scatter of the next).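

In this assay the position on an aromatic carbon ortho to a chloro group takes phenylcarbamoyl, with one six-membered aromatic ring of carbon only and a carbonyl, in place of the two aromatic rings of 2H-indazol-2-yl, and the result is a 1.8-fold higher number from compound 3 to compound 4 (0.24 log units; within the scatter) even though the ring count and hydrogen-bond donor count both change. The exchange for 1,3-benzothiazol-2-yl gives a 2.0-fold higher number from compound 2 to compound 4 (0.30 log units; within the scatter) as well, so compounds 2, 3 and 4 now form one group at this position despite their different atoms. The hydrogen-bond donor that phenylcarbamoyl brings does not return the number to that of compound 1, as a 12-fold higher number from compound 1 to compound 4 (1.07 log units; beyond the scatter) shows, and the 1H-benzimidazol-2-yl group of compound 1 is the only one of the four set apart from the rest. Nothing shown here gives a measured reason for this pattern.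

The compounds shown leave open whether the amide hydrogen of phenylcarbamoyl matters, which an N-methyl-N-phenylcarbamoyl group would test. They also leave open whether the low number of compound 1 would survive a methyl group on the ring nitrogen of 1H-benzimidazol-2-yl.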